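Adding a Second Chloro to the Thiazolidinedione Series

The source may hold more compounds than are shown below. What is called first, only, known or untested is meant among the compounds shown, and "the series" means these compounds.

This account follows four compounds that share a five-membered dione core joined through a methylene to a phenyl ether. Compound 1 `O=C1NC(=O)C(Cc2ccc(Oc3ccc(Cl)cc3Cl)cc2C(F)(F)F)S1` carries a trifluoromethyl group and two chloro groups; in a functional assay for agonist activity at Free fatty acid receptor 1 (Homo sapiens), read by FLIPR, in the presence of a further agent that is not named here (a higher number here means that more compound is needed for the effect, a lower number that less compound is needed), compound 1 gives 88 nM. Compound 2 `O=C1NC(=O)C(Cc2ccc(Oc3ccc(Cl)cc3Cl)cc2)O1` has an oxygen in its core in place of sulfur, and in this assay compound 2 gives 4020 nM. Compound 3 `O=C1NC(=O)C(Cc2ccc(Oc3ccccc3Cl)cc2)S1` has a single chloro group on the ether ring; in this assay compound 3 gives 1190 nM, the second highest number of the three, lying beyond the scatter from both compound 2 and compound 1.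

Compound 4 `O=C1NC(=O)C(Cc2ccc(Oc3ccc(Cl)cc3Cl)cc2)S1` differs from compound 3 in one place: chloro in place of hydrogen on an aromatic carbon, on an aromatic carbon of a six-membered aromatic ring of carbon only. Among the compounds with values here, no measured pair shows this exact step, so the size of the change is uncertain. Compound 4 is expected to give a lower number in this assay than compound 3, a step of a 2.6-fold lower number from compound 3 to compound 4 (0.42 log units; beyond the scatter), which is estimated as 450 nM with a range of 130 nM to 1500 nM.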

Compound 4, half-maximal effective concentration: 101 nM
Beside the measured number, compound 4's estimate is 4.5-fold (0.65 log units) above it; measured number outside the range, below it.
By their numbers in this assay, from the lowest: compounds 1 and 4 (each within the scatter of the next); then compound 3; then compound 2.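

The added chloro, meta to a chloro group and para to a large group, brings a large gain in this series (a 12-fold lower number from compound 3 to compound 4 (1.07 log units; beyond the scatter)), so this position on the ether ring is far from indifferent in this assay. With that same ether in place, the core also matters: 2,4-dioxo-1,3-thiazolidin-5-yl in place of 2,4-dioxo-1,3-oxazolidin-5-yl gives the largest step shown (a 40-fold lower number from compound 2 to compound 4 (1.60 log units; beyond the scatter)). Trifluoromethyl, by contrast, can give way to hydrogen with no change beyond the scatter (a 1.1-fold higher number from compound 1 to compound 4 (0.06 log units; within the scatter)), so it is not needed once both chloro groups are present.

Nothing available gives a reason for the size of these steps. On these data alone, whether a fluoro, methyl or methoxy group could replace the added chloro at this same place stays open, as does whether a carboxylic acid could replace the shared core.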